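Swapping Methoxy for Trifluoromethyl on an Inactive Pair

The source may report more compounds than this note shows. Statements on the series, on what has been measured and on what is new or still open speak of the compounds shown alone.

Measured so far:
compound 1 `CCOC(=O)C1=Cc2ccccc2OC1(OCc1cn(-c2cccc(OC)c2)nn1)C(F)(F)F`: > 150000 nM
compound 2 `CCOC(=O)C1=Cc2ccccc2OC1(OCc1cc(-c2ccc3ccccc3c2)no1)C(F)(F)F`: > 150000 nM

Both compounds share a core and were tested in a functional assay on A549 cells (Homo sapiens) for inhibition, read by MTT assay, with a stated time of 24 h; on this read-out higher numbers stand for weaker inhibition and lower numbers for stronger inhibition. For compound 1 the result > 150000 nM is a limit of the assay rather than a number. For compound 2 the result > 150000 nM is likewise a limit. Within the data shown here, both values therefore sit at the limit of > 150000 nM in this assay, at which 2 of the 2 values shown sit, and no step with a measured size exists between them.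

Compound 3 `CCOC(=O)C1=Cc2ccccc2OC1(OCc1cn(-c2cccc(C(F)(F)F)c2)nn1)C(F)(F)F` differs from compound 1 by trifluoromethyl in place of methoxy on an aromatic carbon. Since compound 1 shows only the limit > 150000 nM, no direction for the change can be read from the numbers. The step that the limit leaves unreadable from compound 1 to compound 3 is expected to stay within the scatter, in either direction. Compound 3 is thus expected to give 200000 nM, within 100000 nM to 400000 nM, most likely again reported as a limit.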

Compound 3, half-maximal inhibitory concentration: > 150000 nM
Compound 3: only a limit was reported (the forecaster's own chance of this, stated with the estimate: 80%); the middle value is on the limit's open side.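

Compound 1 and compound 3 both end at a limit of the assay rather than a number, so no step between them can be read: the limit of > 150000 nM in this assay, at which 3 of the 3 values shown sit.

The compounds shown leave open whether trifluoromethyl in place of methoxy changes inhibition at all.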